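The source may report more compounds than this note shows. Statements on the series, on what has been measured and on what is new or still open speak of the compounds shown alone.

Compound 1 `CC(C)[C@H](NC(=O)COc1cccc2ccccc12)C(=O)N[C@@H](CC(=O)O)C(=O)COc1cccc2cccnc12` and compound 2 `CC(C)[C@H](NC(=O)COc1cccc2ccccc12)C(=O)N[C@@H](CC(=O)O)C(=O)COc1ncnc2ccccc12` share one core and differ only in the aromatic group attached through an oxygen on a saturated carbon. In a functional assay on Jurkat cells (Homo sapiens) for inhibition (a higher number here means a weaker inhibitor, a lower number a stronger inhibitor), compound 1 gives > 200000 nM, which is a limit of the assay rather than a number. In this assay compound 2 likewise gives > 200000 nM, again a limit. The step that the two limits leave unreadable from compound 1 to compound 2 cannot be read in size or direction because the limit of > 200000 nM in this assay, at which 2 of the 2 values shown sit, is all that the two compounds show. Compound 3 `CC(C)[C@H](NC(=O)COc1cccc2ccccc12)C(=O)N[C@@H](CC(=O)O)C(=O)COc1nccc2ccccc12` carries the change (isoquinolin-1-yl in place of quinazolin-4-yl on an oxygen on a saturated carbon). Within the data shown here, no measured step with readable numbers bears on this change; the one step at hand is the unreadable one just described. Compound 3 is therefore expected to remain at the limit as well, which means an estimated step that the limit leaves unreadable from compound 2 to compound 3 of no readable size. For compound 3 the expected value is 300000 nM, with a range from 50000 nM to 2000000 nM.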

Compound 3, half-maximal inhibitory concentration: 106000 nM
Beside the measured number, compound 3's estimate is 2.8-fold (0.45 log units) above it, within the range that was stated.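

Compound 3 is the only one of the three with a measured number rather than a limit: in this assay compound 3 gives 106000 nM. This shows that a change in the aromatic group on an oxygen on a saturated carbon can bring the read-out into the measurable range, with an at least 1.8-fold lower number from compound 2 to compound 3 (0.27 log units; that floor lies within the scatter) and an at least 1.8-fold lower number from compound 1 to compound 3 (0.27 log units; that floor lies within the scatter). Each step is only a floor, and its true size cannot be read, because the other two compounds stay at a limit: the limit of > 200000 nM in this assay, at which 2 of the 3 values shown sit.

The compounds shown leave open how much of this result belongs to isoquinolin-1-yl itself and how much lower the number could go with other groups at this position. A plain phenyl ring in its place, or an isoquinolin-1-yl ring carrying an amine or a carboxylic acid, would be further tests of this position.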